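The source may report more compounds than this note shows. Statements on the series, on what has been measured and on what is new or still open speak of the compounds shown alone.

Three compounds of one series share a core and differ only in the group on an amine nitrogen in a ring. Compound 1 `O=C(c1cccnc1)N1CCC(NS(=O)(=O)c2cc(S(=O)(=O)c3ccccc3)ccc2C(F)(F)F)CC1` gives 120 nM in an assay on U2OS cells for inhibition of secreted frizzled-related protein 1 (Homo sapiens), read by a luciferase reporter, with a stated time of 18 h; a higher number here means that more compound is needed for the effect, a lower number that less compound is needed. Compound 2 `O=S(=O)(NC1CCN(S(=O)(=O)c2ccccc2)CC1)c1cc(S(=O)(=O)c2ccccc2)ccc1C(F)(F)F` gives 210 nM in this assay, and compound 3 `N#Cc1cccc(S(=O)(=O)N2CCC(NS(=O)(=O)c3cc(S(=O)(=O)c4ccccc4)ccc3C(F)(F)F)CC2)c1` gives 170 nM in this assay. On these three numbers compound 3 holds the second highest, with compound 2 nearest and compound 1 furthest, yet every pair lies within the scatter: a 1.8-fold higher number from compound 1 to compound 2 (0.24 log units; within the scatter), a 1.4-fold higher number from compound 1 to compound 3 (0.15 log units; within the scatter), and a 1.2-fold lower number from compound 2 to compound 3 (0.09 log units; within the scatter).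

Compound 4 `O=C(O)CCCC(=O)N1CCC(NS(=O)(=O)c2cc(S(=O)(=O)c3ccccc3)ccc2C(F)(F)F)CC1` has not yet been measured in this assay. It differs from compound 3 at that same ring nitrogen: (3-carboxypropyl)carbonyl in place of (3-cyanophenyl)sulfonyl on an amine nitrogen in a ring. Compound 1 likewise bears a carbonyl group on that nitrogen, and the step of a 1.4-fold higher number from compound 1 to compound 3 (0.15 log units; within the scatter) is the one that bears most directly on this change; it stayed within the scatter, as did a 1.8-fold higher number from compound 1 to compound 2 (0.24 log units; within the scatter) and a 1.2-fold lower number from compound 2 to compound 3 (0.09 log units; within the scatter). Going by the values given here, no measured step here separates a (3-carboxypropyl)carbonyl group from an aromatic group at this position, so no step beyond the scatter is anticipated. Compound 4 is therefore expected to give about 200 nM in this assay, within a range from 70 nM to 600 nM, the expected step of a 1.2-fold higher number from compound 3 to compound 4 (0.07 log units; within the scatter) being no larger than the scatter.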

Compound 4, half-maximal effective concentration: 570 nM
Estimate against measurement, compound 4: 2.9-fold (0.45 log units) below; the measured number falls inside the stated range.
By their numbers in this assay, from the lowest: compounds 1, 3 and 2 (each within the scatter of the next); then compound 4.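

In this assay this ring nitrogen proves not to be indifferent to what it carries: the three earlier groups stayed within the scatter of one another, whereas (3-carboxypropyl)carbonyl lies beyond it against both sulfonyl groups (a 3.4-fold higher number from compound 3 to compound 4 (0.53 log units; beyond the scatter) and a 2.7-fold higher number from compound 2 to compound 4 (0.43 log units; beyond the scatter)), modest steps though they are. Compound 4 keeps a carbonyl on the nitrogen as compound 1 does, yet 3-carboxypropyl in place of pyridin-3-yl on that carbonyl carbon gives the largest of the three steps (a 4.8-fold higher number from compound 1 to compound 4 (0.68 log units; beyond the scatter)), so a carbonyl there does not by itself hold the number at the level of compound 1. Nothing given here accounts for this rise at the ring nitrogen.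

The compounds shown leave open whether the carboxylic acid or the absence of an aromatic ring matters more, as compound 4 differs from compound 1 in both. A methyl ester or a primary amide on the same chain, a longer chain ending in a carboxylic acid, and a benzoyl group bearing a carboxylic acid would each begin to separate the two.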